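Moving the chlorine on the amide-side ring

The compounds below may be only part of what the source reports. "The series", "measured", "known", "first", "only" and "open" are said of these compounds alone.

Of the compounds shown here, three share one core and have been measured in an ADME assay for metabolic stability, read by HPLC, at pH 7.4; a higher number here means that the compound lasts longer, a lower number that the compound disappears faster. Compound 1 `CCCCNC(=O)Oc1ccc(Cl)cc1C(=O)Nc1cccc(Cl)c1` gives 43 h; compound 2 `CCCCCCNC(=O)Oc1ccc(Cl)cc1C(=O)Nc1cccc(Cl)c1` gives 43 h; compound 3 `CCCCCCCCCCCNC(=O)Oc1ccc(Cl)cc1C(=O)Nc1cccc(Cl)c1` gives 43 h. Compound 2 therefore stands level with both neighbours: the step of no change at the digits printed from compound 1 to compound 2 (within the scatter) and the step of no change at the digits printed from compound 2 to compound 3 (within the scatter) are both flat, as is the wider step no change at the digits printed from compound 1 to compound 3 (within the scatter).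

Compound 4 `CCCCCCNC(=O)Oc1ccc(Cl)cc1C(=O)Nc1ccc(Cl)cc1` has not yet been measured. It differs from compound 2 in one place only: 4-chlorophenyl in place of 3-chlorophenyl on an amide-type nitrogen.

Going by the values given here, each of the three measured steps alters the saturated chain attached to the carbamate-type nitrogen; none of them touches the chlorophenyl ring on the amide-type nitrogen, so no measured step speaks directly to the change from compound 2 to compound 4. What the data do show is that this assay has returned the same reading for every variation tried so far. Among the compounds with values here, with no direct precedent, the most defensible expectation is a step of no change at the digits printed from compound 2 to compound 4 (within the scatter) of no size beyond the scatter. Compound 4 is therefore estimated at 43 h, with a range from 20 h to 90 h.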

Compound 4, half-life: 43 h
The estimate for compound 4 equals the measured number at the digits printed; the measured number falls inside the stated range.
By their numbers in this assay, from the lowest: compounds 1, 2, 3 and 4 (each within the scatter of the next).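

In this assay, going by these compounds alone, the move from 3-chlorophenyl to 4-chlorophenyl on the amide-type nitrogen gives the step of no change at the digits printed from compound 2 to compound 4 (within the scatter), the first reading from this part of the molecule, as all the earlier steps changed only the saturated chain on the carbamate-type nitrogen. The result shows that this one rearrangement, which keeps the same atoms and joins them differently, leaves the half-life level, so the flat reading now extends beyond changes in chain length to one change in where the chlorine sits on this ring. No measurement shown here bears on why the reading stays level, and this single step gives no explanation of its own.

The chlorine itself stays in place in every compound shown, so it remains open whether a nitrile, a trifluoromethyl or an amine on this ring, or an unsubstituted phenyl on the amide-type nitrogen, would give a step beyond the scatter. All four compounds read alike, which also leaves open which change to the shared core, if any, would move the half-life in either direction.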